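The compounds below may be only part of what the source reports. "The series", "measured", "known", "first", "only" and "open" are said of these compounds alone.

In an ADME assay on LLC-MK2 cells (Macaca mulatta) for cytotoxicity, read by spectrophotometry and crystal violet staining, with a stated time of 4 days (on this read-out higher numbers stand for lower toxicity in this test and lower numbers for higher toxicity in this test), compound 1 `CC(C)n1ncc2c(C(=O)Nc3ccc(F)cc3)cc(-c3cccs3)nc21` gives > 200000 nM, a limit of the assay and not a number. Compound 3 `CC(C)n1ncc2c(C(=O)Nc3ccc(F)c(F)c3)cc(-c3cccs3)nc21` gives > 200000 nM, also a limit, and together they mark (the limit of > 200000 nM in this assay, at which 2 of the 3 values shown sit). Compound 2 `CC(C)n1ncc2c(C(=O)N3CCc4cccnc43)cc(-c3cccs3)nc21` gives 50000 nM. Compound 4 `CC(C)n1ncc2c(C(=O)Nc3ccc(F)cc3)cc(C3CC3)nc21` carries cyclopropyl in place of thiophen-2-yl on an aromatic carbon of the core of compound 1 (cyclopropyl in place of thiophen-2-yl on an aromatic carbon). The two readable steps, an at least 4.0-fold lower number from compound 1 to compound 2 (0.60 log units; beyond the scatter) and an at least 4.0-fold higher number from compound 2 to compound 3 (0.60 log units; beyond the scatter), both change the group on the carbonyl carbon, and the fluoro step that the two limits leave unreadable from compound 1 to compound 3 cannot be sized. None of them touches this position, so no step beyond the scatter is expected. The expected change is a number no higher from compound 1 to compound 4 (the limit leaves the size open). Compound 4 is estimated at 200000 nM, with an expected range from 60000 nM to 400000 nM.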

Compound 4, half-maximal cytotoxic concentration: 12500 nM
Compound 4: the middle estimate sits 16-fold (1.20 log units) above what was measured, outside the stated range (below it).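

In this assay, cyclopropyl in place of thiophen-2-yl gives an at least 16-fold lower number from compound 1 to compound 4 (1.20 log units; beyond the scatter), toward higher toxicity in this test. The group on this aromatic carbon therefore moves the read-out too, and not only the group on the carbonyl carbon. The value of compound 1 is a limit and not a number, so the full size of this step stays open: the limit of > 200000 nM in this assay, at which 2 of the 4 values shown sit.

From the compounds shown here alone, whether phenyl, isopropyl or an amine at this position would read closer to compound 1 or to compound 4 stays open. Also open, going by these compounds, is whether the same exchange gives a comparable step with the carbonyl group of compound 2.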